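Swapping methoxy for bromo on a shared core

The source may hold more compounds than are shown below. What is called first, only, known or untested is meant among the compounds shown, and "the series" means these compounds.

Within the data shown here, compound 2 `COc1ccc2c(c1)C(=O)C(=O)N2CCCn1cc(COc2cc(=O)oc3ccccc23)nn1` is one of two compounds so far measured in a functional assay on COLO 205 cells (Homo sapiens) for inhibition, read by sulforhodamine B assay, with a stated time of 48 h, tested at 50 uM (on this read-out lower numbers stand for less inhibition of growth and higher numbers for more inhibition of growth at the one concentration tested), where compound 2 gives 48%. This is the lower of the two numbers: compound 1 `O=C1C(=O)N(CCCn2cc(COc3cc(=O)oc4ccccc34)nn2)c2ccc(F)cc21` gives 69% in this assay, and the only difference between them is a methoxy in place of fluoro on an aromatic carbon, a change that went a number 21 percentage points lower from compound 1 to compound 2 (beyond the scatter). Compound 3 `O=C1C(=O)N(CCCn2cc(COc3cc(=O)oc4ccccc34)nn2)c2ccc(Br)cc21` has not yet been measured in this assay. It differs from compound 2 by bromo in place of methoxy on an aromatic carbon. Among the measured compounds shown here, the single measured step bears on this only indirectly: it shows that replacing the halogen fluoro by methoxy lowered the number, so taking the methoxy away again in favour of another halogen, bromo, is expected to recover some or all of that loss, a step of a number 17 percentage points higher from compound 2 to compound 3 (beyond the scatter). Compound 3 is therefore estimated at 65% in this assay, with a range from 45% to 85%.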

Compound 3, percent growth inhibition at one concentration: 61%
Estimate against measurement, compound 3: 4 percentage points above, and the stated range covers the measured number.
By their numbers in this assay, from the lowest: compound 2; then compounds 3 and 1 (each within the scatter of the next).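

In this assay, bromo in place of methoxy gives a number 13 percentage points higher from compound 2 to compound 3 (beyond the scatter), which shows that the lower number for methoxy also appears against a second halogen and not against fluoro alone. Bromo in place of fluoro gives a number 8 percentage points lower from compound 1 to compound 3 (within the scatter), so at this aromatic carbon the two halogens cannot be told apart, while methoxy stands apart from both. Nothing available here explains why methoxy differs from these two halogens.

The compounds shown leave open how chloro, an amine or a carboxylic acid on this same aromatic carbon would compare with the halogens and with methoxy. They also leave open whether ethoxy, with its longer chain on the oxygen, would match methoxy.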